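A few compounds are considered here, and "the series" means these few. Any claim that something is new, unique, unknown or untested is made for them only; others in the source may bear on it.

Compound 1 `Cc1ccc(Cn2c(CC3CCCC3)nc3ccccc32)cc1`: 8600 nM
Compound 2 `Clc1ccc(Cn2c(CC3CCCC3)nc3ccccc32)cc1`: 3300 nM

Both numbers come from an assay on microsomes from brain for inhibition of heme oxygenase 2 (Rattus norvegicus), using NADPH, with stated times of 10 min and 15 min; on this read-out higher numbers stand for weaker inhibition and lower numbers for stronger inhibition. Compound 2 stands lowest of the two, with compound 1 above it by a 2.6-fold lower number from compound 1 to compound 2 (0.42 log units; beyond the scatter), a change of chloro in place of methyl on an aromatic carbon. Compound 3 `Brc1ccc(Cn2c(CC3CCCC3)nc3ccccc32)cc1` differs from compound 2 by bromo in place of chloro on an aromatic carbon. For the measured compounds named here, the one measured step does not cover this swap of two halogens, so it bears on it only loosely, as a sign that this position tolerates change. For compound 3 a small step, a 1.3-fold lower number from compound 2 to compound 3 (0.12 log units; within the scatter), is expected, within the scatter. The estimate for compound 3 is 2500 nM, ranging from 1000 nM to 6500 nM.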

Compound 3, half-maximal inhibitory concentration: 8400 nM
Compound 3: middle estimate off by 3.4-fold (0.53 log units), on the low side; the whole stated range lies below it.
By their numbers in this assay, from the lowest: compound 2; then compounds 3 and 1 (each within the scatter of the next).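

Two neighbouring halogens are not interchangeable at this place on the ring: the change to 4-bromophenyl brings a 2.5-fold higher number from compound 2 to compound 3 (0.41 log units; beyond the scatter) and so takes back the gain that chloro gave over methyl. Bromo in place of methyl gives a 1.0-fold lower number from compound 1 to compound 3 (0.01 log units; within the scatter) and leaves chloro as the only one of the three groups that stands apart. No measurement here speaks to the reason for this difference. Going by these compounds, whether fluoro, methoxy or an amine at this place would track chloro or bromo stays open. So does whether chloro keeps its edge with a different group in place of the cyclopentylmethyl chain.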